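This account rests on a few compounds, and the source may have more. Where it says the series, first, only, none or still open, it means among the compounds named here.

Compound 1 `CCC(C)(C)C(=O)N(O)Cc1cc(F)cc(F)c1F` gives 0.154 h
Compound 2 `CCC(C)(C)C(=O)N(O)Cc1ccc(F)c(F)c1F` gives 0.232 h

In an ADME assay on microsomes from liver (Mus musculus) for metabolic stability, read by LC-MS, using NADPH (on this read-out lower numbers stand for a shorter-lived compound and higher numbers for a longer-lived compound), compound 2 gives 0.232 h, which lies within the usual scatter of repeated measurements of compound 1 at 0.154 h. Among the measured compounds shown here, compound 2 therefore stands level with the only other measured compound. Compound 3 `CCC(C)(C)C(=O)N(O)Cc1ccc(F)cc1F` follows from compound 2 through one change (hydrogen in place of fluoro on an aromatic carbon), with hydrogen in place of fluoro on an aromatic carbon. For the measured compounds named here, no measured pair shows what this swap does in this assay, so the estimate rests only on the closeness of these two values, although the fluoro groups of compound 1 and compound 2 are placed differently. No shift beyond the scatter is expected, and the estimated step is a 1.2-fold lower number from compound 2 to compound 3 (0.09 log units; within the scatter). For compound 3 the expected half-life is 0.19 h, within an estimated range of 0.1 h to 0.36 h.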

Compound 3, half-life: 0.387 h
The estimate for compound 3 lay 2.0-fold (0.31 log units) below the measured number, and the stated range ends below it.
By their numbers in this assay, from the lowest: compounds 1, 2 and 3 (each within the scatter of the next, the first and the last beyond it).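

In this assay, among the compounds shown here, compounds 2 and 3 give the first pair that differs in one place only, and putting hydrogen in place of the fluoro group gives a 1.7-fold higher number from compound 2 to compound 3 (0.22 log units; within the scatter). At this position, ortho to two fluoro groups and meta to a large group, the swap therefore produces no difference that stands clear of the usual scatter, so this fluoro group is not shown to matter for the half-life on this evidence. Nothing available explains this result.

A single pair cannot show whether the same swap would behave alike at another place on the ring or on a different core. It also leaves open what a larger or different group at this position, such as a methoxy group, an amine or a chlorine atom, would do to the half-life.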